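This account rests on a few compounds, and the source may have more. Where it says the series, first, only, none or still open, it means among the compounds named here.

Measured so far:
- compound 1 `O=c1[nH]c2ccc(-c3csc(-c4ccc(F)c(F)c4)n3)cc2o1` gives 290 nM
- compound 2 `Cc1cc(-c2nc(-c3ccc4[nH]c(=O)oc4c3)cs2)ccc1F` gives 250 nM

Both values come from a functional assay on SMOV2 cells (Homo sapiens) for antiproliferative activity, read by sulforhodamine B assay, with a stated time of 3 days (a lower number here means a stronger inhibitor of growth, a higher number a weaker inhibitor of growth), and lie within the scatter of each other, so compound 2 stands level with compound 1.

Compound 3 `O=c1[nH]c2ccc(-c3csc(-c4ccc(F)c(C(F)(F)F)c4)n3)cc2o1` carries trifluoromethyl in place of methyl on an aromatic carbon, ortho to a fluoro group: trifluoromethyl in place of methyl on an aromatic carbon.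

Going by the values given here, the only measured step bearing on this place is a 1.2-fold lower number from compound 1 to compound 2 (0.06 log units; within the scatter), methyl in place of fluoro, and it stays within the scatter. It gives no ground for expecting a real shift in either direction, though one step is thin evidence. The expected change is a 1.1-fold higher number from compound 2 to compound 3 (0.03 log units; within the scatter), which is no step beyond the scatter.

For compound 3 the estimated value is 270 nM, with an expected range of 100 nM to 700 nM.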

Compound 3, concentration for 50% growth inhibition: > 50000 nM
Compound 3: a limit, no number (the forecaster's own chance of this, stated with the estimate: 2%); at least 180-fold (2.26 log units) between middle value and limit.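

In this assay, this position turns out not to accept every group: methyl and fluoro stand level here, yet trifluoromethyl brings an at least 200-fold higher number from compound 2 to compound 3 (2.30 log units; beyond the scatter), and in place of fluoro it brings an at least 170-fold higher number from compound 1 to compound 3 (2.23 log units; beyond the scatter). The change from methyl to trifluoromethyl on this aromatic carbon, ortho to a fluoro group, is therefore far from neutral. Compound 3 gives a limit and not a number: the limit of > 50000 nM in this assay, at which 1 of the 3 values shown sits.

Still open, as far as these compounds go, is whether chloro, methoxy or an amine at this place would behave like methyl or like trifluoromethyl. Also open, from the compounds shown here alone, is whether trifluoromethyl would give the same result on a ring without the fluoro group.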